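The source may hold more compounds than are shown below. What is called first, only, known or untested is meant among the compounds shown, and "the series" means these compounds.

Working notes on the series. Compound 1 `OCc1cc2cc(/C(=N\O)Nc3cccc(F)c3)ccc2o1` and compound 2 `COCc1cc2cc(/C(=N\O)Nc3cccc(F)c3)ccc2o1` share one core and differ only at the group on the oxygen attached to a saturated carbon. In an assay on isolated protein for inhibition of Indoleamine 2,3-dioxygenase 1 (Homo sapiens), read by spectrophotometry (on this read-out lower numbers stand for stronger inhibition and higher numbers for weaker inhibition), compound 1 gives 1700 nM, and compound 2 gives 7100 nM. Among the compounds with values here, the step of a 4.2-fold higher number from compound 1 to compound 2 (0.62 log units; beyond the scatter) is the only measured change in this assay, and it runs toward weaker inhibition. Within the data shown here, compound 2 therefore stands with the highest number of the two measured compounds, with compound 1 as its only neighbour.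

Compound 3 `O/N=C(/Nc1cccc(F)c1)c1ccc2oc(COCC3CC3)cc2c1` is not yet measured. It differs from compound 2 by cyclopropyl in place of hydrogen on a saturated chain carbon bound to an oxygen on a saturated carbon, a further growth at the same end of the molecule where the methyl was added. Among the measured compounds shown here, the one step that bears on this region, a 4.2-fold higher number from compound 1 to compound 2 (0.62 log units; beyond the scatter), was modest and beyond the scatter in the direction of a higher number. For the measured compounds named here, no measured step shows what a larger group at this position does, so a move of similar size in the same direction, or none beyond the scatter, is both plausible. On that basis compound 3 is expected to give about 9000 nM in this assay, within a range of 3000 nM to 30000 nM, which corresponds to an estimated step of a 1.3-fold higher number from compound 2 to compound 3 (0.10 log units; within the scatter).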

Compound 3, half-maximal inhibitory concentration: 2200 nM
Beside the measured number, compound 3's estimate is 4.1-fold (0.61 log units) above it; measured number outside the range, below it.
By their numbers in this assay, from the lowest: compounds 1 and 3 (each within the scatter of the next); then compound 2.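

In this assay, cyclopropyl in place of hydrogen on a saturated chain carbon bound to an oxygen on a saturated carbon gives a 3.2-fold lower number from compound 2 to compound 3 (0.51 log units; beyond the scatter), so the earlier step of a 4.2-fold higher number from compound 1 to compound 2 (0.62 log units; beyond the scatter) does not continue as a trend when the group on this oxygen grows. Cyclopropylmethyl in place of hydrogen on the same oxygen gives a 1.3-fold higher number from compound 1 to compound 3 (0.11 log units; within the scatter), which shows that this position accepts the larger ether group without a change beyond the scatter, and that across these three compounds the number does not follow the size of the group, with compound 2 standing apart from compound 1 and compound 3. Nothing measured here accounts for the methyl ether standing apart from the other two compounds.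

The compounds shown leave open whether the cyclopropyl ring itself matters or any group of this length would do, a question that an ethyl, a propyl or a longer chain on the same oxygen would address. They also leave open how this position responds to a group of another kind, such as an amine or a carboxylic acid at the end of the chain.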